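The source may report more compounds than this note shows. Statements on the series, on what has been measured and on what is new or still open speak of the compounds shown alone.

Measured so far in an assay on C6 glioma cells for displacement of a labelled ligand from sodium- and chloride-dependent glycine transporter 1 (Rattus norvegicus), read by scintillation counting, with stated times of 30 min and 10 min; on this read-out lower numbers stand for stronger inhibition and higher numbers for weaker inhibition:
compound 1 `CCc1nnc(-c2ccc(-c3ccccc3)cc2)n1-c1ccccc1C` gives 300 nM
compound 2 `CCc1nnc(-c2ccc(-c3ccccc3)cc2)n1-c1cccc(C)c1C` gives 940 nM

For the measured compounds named here, compound 2 stands at the higher of these two numbers in this assay, and the only measured step, a 3.1-fold higher number from compound 1 to compound 2 (0.50 log units; beyond the scatter), is the whole of what is known about change at this place. Compound 3 `CCc1nnc(-c2ccc(-c3ccccc3)cc2)n1-c1cccc(N)c1C` differs from compound 2 by amino in place of methyl on an aromatic carbon. Going by the values given here, no measured step swaps one group for another at this carbon; the one step that bears on the site, a 3.1-fold higher number from compound 1 to compound 2 (0.50 log units; beyond the scatter), shows only that a methyl entering there raises the number beyond the scatter. Whether an amino in its place keeps, undoes or adds to that rise, the two measured compounds cannot tell. The step is therefore expected to be a 1.0-fold lower number from compound 2 to compound 3 (0.02 log units; within the scatter), within the scatter but with a wide range. Compound 3 is estimated at 900 nM, between 300 nM and 3000 nM.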

Compound 3, half-maximal inhibitory concentration: 320 nM
Estimate against measurement, compound 3: 2.8-fold (0.45 log units) above, within the range that was stated.
By their numbers in this assay, from the lowest: compounds 1 and 3 (each within the scatter of the next); then compound 2.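

In this assay this carbon proves to respond to which group stands on it and not merely to its being filled: amino in place of methyl gives a 2.9-fold lower number from compound 2 to compound 3 (0.47 log units; beyond the scatter) and so takes away the rise that the methyl brought. Set against hydrogen at the same carbon, amino gives a 1.1-fold higher number from compound 1 to compound 3 (0.03 log units; within the scatter) and the two compounds cannot be told apart in this assay. No measured evidence accounts for the different outcome with these two groups.

As far as these compounds go, neither methyl nor amino takes the number beyond the scatter below that of compound 1, so it remains open whether any group on this carbon can do so. A hydroxyl, a methoxy or an acetamide there would show whether this tolerance belongs to amino alone or extends to other groups.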